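From Cyclopentyl Ester to Cyclobutylmethyl Ester on a Shared Core

The source may report more compounds than this note shows. Statements on the series, on what has been measured and on what is new or still open speak of the compounds shown alone.

Of the compounds shown here, two on a shared core have been measured in an assay on membranes from HEK293 cells for displacement of a labelled ligand from adenosine receptor A2b (Homo sapiens), read by scintillation counting, with a stated time of 30 min; a higher number here means a weaker inhibitor, a lower number a stronger inhibitor. Compound 1 `CC1=C(C(=O)OCC2CCC2)C(c2ccoc2)NC(=O)N1` gives 739 nM, and compound 2 `CC1=C(C(=O)OC2CCCC2)C(c2ccsc2)NC(=O)N1` gives 659 nM. Compound 2 has the lowest of the two numbers, but compound 1 sits within the usual scatter of it, so the two cannot be placed in an order. These two compounds differ in more than one place, and no single change between them has been sized. Compound 3 `CC1=C(C(=O)OCC2CCC2)C(c2ccsc2)NC(=O)N1` has not yet been measured. It differs from compound 2 by cyclobutylmethyl in place of cyclopentyl on an oxygen next to a carbonyl group. Nothing measured here sizes that change on its own, so it is taken as a step with no clear direction and no size beyond the scatter. For compound 3 the estimate in this assay is 700 nM, with a range from 350 nM to 1400 nM. The expected step of a 1.1-fold higher number from compound 2 to compound 3 (0.03 log units; within the scatter) is accordingly small, and its sign is uncertain.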

Compound 3, inhibition constant: 1040 nM
For compound 3 the middle estimate is 1.5-fold (0.17 log units) below the measured one, and the stated range covers the measured number.
By their numbers in this assay, from the lowest: compounds 2, 1 and 3 (each within the scatter of the next).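

In this assay the change from cyclopentyl to cyclobutylmethyl on an oxygen next to a carbonyl group now has a size of its own, a 1.6-fold higher number from compound 2 to compound 3 (0.20 log units; within the scatter), so at this position the two groups cannot be told apart. With cyclobutylmethyl held in place, thiophen-3-yl in place of furan-3-yl on a saturated ring carbon also has a size, a 1.4-fold higher number from compound 1 to compound 3 (0.15 log units; within the scatter), and this pair cannot be told apart either. Nothing measured on these compounds speaks to the reason for these results.

The compounds shown leave open whether an ester carrying a longer chain, an amine or a carboxylic acid would give a step beyond the scatter. They also leave open how cyclopentyl behaves alongside furan-3-yl on the shared core.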